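Branched Alkyl in Place of Hydroxyethyl on the Ring Nitrogen

A few compounds are considered here, and "the series" means these few. Any claim that something is new, unique, unknown or untested is made for them only; others in the source may bear on it.

Compound 1, `CCOCCn1c(N2CCN(C)CC2)nc2ccccc21`: 10 nM
Compound 2, `CCCC(C)Cn1c(N2CCN(C)CC2)nc2ccccc21`: 500 nM
Compound 3, `CN1CCN(c2nc3ccccc3n2CCO)CC1`: 410 nM

In a functional assay on ileum for inhibition of histamine H1 receptor (Cavia porcellus) (a lower number here means a stronger inhibitor, a higher number a weaker inhibitor), compound 3 gives the second highest of the three numbers; its nearest neighbour is compound 2, at a 1.2-fold lower number from compound 2 to compound 3 (0.09 log units; within the scatter), and its furthest is compound 1, at a 41-fold higher number from compound 1 to compound 3 (1.61 log units; beyond the scatter). Compound 4, `CCCC(C)n1c(N2CCN(C)CC2)nc2ccccc21`, differs from compound 3 by 1-methylbutyl in place of 2-hydroxyethyl on an aromatic nitrogen. Going by the values given here, the step that bears on this is the one from compound 2 to compound 3, where a hydroxymethyl stood in for a 1-methylbutyl on the chain carbon and gave a 1.2-fold lower number from compound 2 to compound 3 (0.09 log units; within the scatter). The large steps of a 50-fold higher number from compound 1 to compound 2 (1.70 log units; beyond the scatter) and a 41-fold higher number from compound 1 to compound 3 (1.61 log units; beyond the scatter) both lead away from compound 1 and do not point to a gain here. For compound 4 no step beyond the scatter is therefore expected, a 1.0-fold lower number from compound 3 to compound 4 (0.01 log units; within the scatter), giving an estimated 400 nM in this assay, with a range of 100 nM to 1600 nM.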

Compound 4, half-maximal inhibitory concentration: 1400 nM
Compound 4: the middle estimate sits 3.5-fold (0.54 log units) below what was measured; measured number inside the range.
By their numbers in this assay, from the lowest: compound 1; then compounds 3 and 2 (each within the scatter of the next); then compound 4.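

In this assay, the 2-methylpentyl and 2-hydroxyethyl groups had stood within the scatter of each other, but 1-methylbutyl on the aromatic nitrogen falls behind both (a 3.4-fold higher number from compound 3 to compound 4 (0.53 log units; beyond the scatter); a 2.8-fold higher number from compound 2 to compound 4 (0.45 log units; beyond the scatter)), so these two branched alkyl chains are not interchangeable here. The 2-ethoxyethyl group keeps by far the lowest number (a 140-fold higher number from compound 1 to compound 4 (2.15 log units; beyond the scatter)). Nothing given here explains these differences. The compounds shown leave open how an unbranched pentyl chain or a 2-methoxyethyl group would compare on this nitrogen. They also leave open the effect of an amine at the end of the ethyl chain.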